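Bromoalkyl chain to benzyl on the shared core

The source may hold more compounds than are shown below. What is called first, only, known or untested is meant among the compounds shown, and "the series" means these compounds.

In a functional assay on HL-60 cells (Homo sapiens) for cytotoxicity, read by MTT assay, with a stated time of 24 h (on this read-out higher numbers stand for weaker inhibition and lower numbers for stronger inhibition), compound 1 `BrCCCCCCOc1c(Br)cc(Br)cc1Oc1ccc(Br)cc1Br` gives 37.8 ug/mL and compound 2 `BrCCCCCOc1c(Br)cc(Br)cc1Oc1ccc(Br)cc1Br` gives 25.7 ug/mL. Within the data shown here, these are the only two values so far, and compound 2 stands within the scatter of compound 1, so the two cannot be ranked.

Compound 3 `Brc1ccc(Oc2cc(Br)cc(Br)c2OCc2ccccc2)c(Br)c1` is reached from compound 2 by a single change: phenyl in place of 4-bromobutyl on a saturated chain carbon bound to an oxygen on an aromatic ring. In words, phenyl replaces 4-bromobutyl on a saturated chain carbon bound to an oxygen on an aromatic ring, which also reads as 5-bromopentyl to benzyl.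

Among the measured compounds shown here, only one measured step bears on this change: a 1.5-fold lower number from compound 1 to compound 2 (0.17 log units; within the scatter). That step swaps bromo for bromomethyl on the chain and brings in no ring, so it is weak guidance for a change of this kind. For the measured compounds named here, no measured compound carries phenyl at this place. With compound 2 at 25.7 ug/mL as the anchor, no shift beyond the scatter is expected in this assay, and no direction is favoured.

The expected change is a 1.1-fold higher number from compound 2 to compound 3 (0.04 log units; within the scatter), an estimate that carries wide uncertainty.

For compound 3 the estimated value is 28 ug/mL, with an expected range of 11 ug/mL to 70 ug/mL.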

Compound 3, half-maximal inhibitory concentration: 27.9 ug/mL
For compound 3 the middle estimate is 1.0-fold (0.00 log units) above the measured one; low and high end bracket the measured number.
By their numbers in this assay, from the lowest: compounds 2, 3 and 1 (each within the scatter of the next).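

Swapping the bromine-ended chain for a ring at this saturated chain carbon bound to an oxygen on an aromatic ring leaves this assay within the scatter, both against the 5-bromopentyl compound (a 1.1-fold higher number from compound 2 to compound 3 (0.04 log units; within the scatter)) and against the longer bromoalkyl chain (a 1.4-fold lower number from compound 1 to compound 3 (0.13 log units; within the scatter)). Among these compounds, until now, the position had been seen only with open bromoalkyl chains; compound 3 shows that 5-bromopentyl to benzyl, which removes the chain-end bromine and brings in one six-membered aromatic ring of carbon only, gives no step beyond the scatter, so for these three compounds neither the bromine-ended chain nor the ring separates on this read-out. No measured information is available here to account for this result.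

Among the compounds shown here, no step among the three compounds lies beyond the scatter, so it remains open whether any group at this place can shift the number appreciably. A chain ending in an amine or a carboxylic acid, a longer chain, or a benzyl carrying a methoxy group on its ring would each test this, and the compounds shown give no indication of the outcome for any of them.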